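A Second Methoxy Step on the Core of Compound 1

The compounds below may be only part of what the source reports. "The series", "measured", "known", "first", "only" and "open" are said of these compounds alone.

Among the compounds with values here, in a functional assay for inhibition, with Rattus norvegicus as the target (a higher number here means a weaker inhibitor, a lower number a stronger inhibitor), compound 1 (`CC(C)CCn1ccc2ccccc21`) gives 3260 nM, the higher of the two numbers measured so far. The other number belongs to compound 2 (`COc1ccc2ccn(CCC(C)C)c2c1`), which gives 775 nM. Compound 3 (`COc1ccc2c(ccn2CCC(C)C)c1`) has not yet been measured. Its difference from compound 1 is methoxy in place of hydrogen on an aromatic carbon.

Within the data shown here, only one measured step bears on this change, a 4.2-fold lower number from compound 1 to compound 2 (0.62 log units; beyond the scatter). It is a modest step of the same kind, and it lies beyond the scatter. A single step cannot show how much the place of the methoxy matters, so it supports only a cautious expectation. A lower number is expected in this assay, though by less than the measured step, and a result within the scatter of compound 1 would not be surprising. The estimated change is a 2.5-fold lower number from compound 1 to compound 3 (0.40 log units; beyond the scatter). For compound 3, the expected value is 1300 nM, with an estimated range of 400 nM to 3800 nM.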

Compound 3, half-maximal inhibitory concentration: 4290 nM
Compound 3: middle estimate off by 3.3-fold (0.52 log units), on the low side; measured number above the stated range.
By their numbers in this assay, from the lowest: compound 2; then compounds 1 and 3 (each within the scatter of the next).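

In this assay, placing the methoxy as it stands in compound 3 gives no change that can be told from the scatter: a 1.3-fold higher number from compound 1 to compound 3 (0.12 log units; within the scatter). Set beside a 4.2-fold lower number from compound 1 to compound 2 (0.62 log units; beyond the scatter), which lies beyond the scatter, this shows that methoxy in place of hydrogen does not carry a single effect across the core of compound 1, and that the outcome of the change depends on which aromatic carbon receives the group. No measured information is at hand to account for this difference between the two places.

The compounds shown leave open whether a group other than methoxy, such as a hydroxyl, a fluorine or an amine, would move the number at the aromatic carbon used in compound 3, and how methoxy would fare on the other aromatic carbons of the shared core. Within the data shown here, they also leave open whether a longer chain in place of the one carried by compound 1 would alter the contrast between the two methoxy places.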